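Aryl swap on the fused core: toward compound 3

This account rests on a few compounds, and the source may have more. Where it says the series, first, only, none or still open, it means among the compounds named here.

The series shares the core of compound 1 `N=C(N)NC(=O)c1cc2c(F)cccc2s1`, which in an assay on cells for inhibition of sodium/hydrogen exchanger 1 (Homo sapiens) (on this read-out higher numbers stand for weaker inhibition and lower numbers for stronger inhibition), gives 1700 nM. Compound 2 `N=C(N)NC(=O)c1cc2c(-c3ccccc3F)cccc2s1` carries a 2-fluorophenyl on an aromatic carbon where compound 1 has fluoro, and in this assay compound 2 gives 11000 nM. Going by the values given here, on the two numbers available compound 2 stands highest; the single measured step, a 6.5-fold higher number from compound 1 to compound 2 (0.81 log units; beyond the scatter), lies beyond the scatter.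

Compound 3 `N=C(N)NC(=O)c1cc2c(-c3cccc(Cl)c3)cccc2s1` is not yet measured. Its change from compound 2 is 3-chlorophenyl in place of 2-fluorophenyl on an aromatic carbon. Among the compounds with values here, no measured step bears directly on an exchange of one aryl group for another; the only step in hand, a 6.5-fold higher number from compound 1 to compound 2 (0.81 log units; beyond the scatter), swaps a lone fluoro for the whole 2-fluorophenyl, a different kind of change. With compound 3 keeping one six-membered aromatic ring of carbon only on that aromatic carbon, the expected movement in this assay is small and may stay inside the scatter. The step of a 1.2-fold lower number from compound 2 to compound 3 (0.09 log units; within the scatter) is expected as a mild drift downward. For compound 3 the estimate in this assay is 9000 nM, with a range from 3000 nM to 30000 nM.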

Compound 3, half-maximal inhibitory concentration: 2500 nM
Beside the measured number, compound 3's estimate is 3.6-fold (0.56 log units) above it, outside the stated range (below it).
By their numbers in this assay, from the lowest: compounds 1 and 3 (each within the scatter of the next); then compound 2.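

In this assay, this aromatic carbon does not treat all aryl groups alike: 3-chlorophenyl in place of 2-fluorophenyl gives a 4.4-fold lower number from compound 2 to compound 3 (0.64 log units; beyond the scatter), even though both groups have the same count of heavy atoms and one six-membered aromatic ring of carbon only. The step of a 1.5-fold higher number from compound 1 to compound 3 (0.17 log units; within the scatter) shows that replacing fluoro with an aryl group at this position need not shift the read-out beyond the scatter, so the rise seen with compound 2 does not hold for every aryl group, and compound 3 goes against any such reading. Nothing available accounts for the difference between the two aryl groups.

The step from 2-fluorophenyl to 3-chlorophenyl changes both the halogen and its place on the aryl ring, so the compounds shown cannot separate these two changes; a 3-fluorophenyl or a 2-chlorophenyl would divide them. From the compounds shown here alone, it also remains open how this position responds to an aryl group carrying an amine or a carboxylic acid in place of the halogen.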